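The source may hold more compounds than are shown below. What is called first, only, known or untested is meant among the compounds shown, and "the series" means these compounds.

Measured so far:

compound 1, `CS(=O)(=O)Oc1c(C(=O)NCc2ccc(F)cc2)nc(Br)c2cccnc12` — > 20000 nM
compound 2, `COC(=O)CNc1c(C(=O)NCc2ccc(F)cc2)nc(Br)c2cccnc12` — > 10000 nM

In a functional assay on HCT-116 cells (Homo sapiens) for cytotoxicity, read by MTT assay, with a stated time of 72 h (on this read-out higher numbers stand for weaker inhibition and lower numbers for stronger inhibition), compound 1 gives > 20000 nM, which is a limit of the assay rather than a number. Compound 2 gives > 10000 nM in this assay, again a limit. The step that the two limits leave unreadable from compound 1 to compound 2 cannot be read because the limit of > 10000 nM in this assay, at which 1 of the 2 values shown sits, and the limit of > 20000 nM in this assay, at which 1 of the 2 values shown sits, cap both values. So compound 2 stands only at a limit, and the one other value shown is a limit as well.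

Compound 3 is `C[C@H](Nc1c(C(=O)NCc2ccc(F)cc2)nc(Br)c2cccnc12)c1ccccc1`. Its difference from compound 2 is 1-phenylethyl in place of (methoxycarbonyl)methyl on a nitrogen on an aromatic ring: 1-phenylethyl enters where (methoxycarbonyl)methyl leaves, on a nitrogen on an aromatic ring whose other neighbour is an aromatic carbon. Going by the values given here, the only measured step, a step that the two limits leave unreadable from compound 1 to compound 2, concerns a different position and has no readable size, so no measured step bears directly on this change. The values available give no direction to expect in this assay beyond the scatter. Compound 3 is therefore estimated at 15000 nM, within 3000 nM to 60000 nM. This estimate means an expected step that the limit leaves unreadable from compound 2 to compound 3, with a fair chance that only a limit is reported again.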

Compound 3, half-maximal inhibitory concentration: > 20000 nM
Compound 3 gave a limit, no number; the forecaster's own chance of this, stated with the estimate: 60%; middle value at least 1.3-fold (0.12 log units) from the limit.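

In this assay compound 3 gives > 20000 nM, again a limit and not a number. No step can be read from compound 2 to compound 3 or from compound 1 to compound 3, as both pairs rest on limits alone. The compounds shown leave open how strongly any of them acts in this assay, and whether the groups that differ among them matter at all.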